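Cytotoxicity notes: iodo to 3-hydroxyphenyl on the core

A few compounds are considered here, and "the series" means these few. Any claim that something is new, unique, unknown or untested is made for them only; others in the source may bear on it.

Compound 1 `Cc1cc(I)c2ncc(CSCCc3ccccc3)n2c1` and compound 2 `Cc1cc(I)cn2c(CSCCc3ccccc3)cnc12` carry the same side chain on closely related fused cores. In an ADME assay on HEL cells (Homo sapiens) for cytotoxicity, with a stated time of 3 days (on this read-out higher numbers stand for lower toxicity in this test and lower numbers for higher toxicity in this test), compound 1 gives > 50 ug/mL, which is a limit of the assay and not a number. In this assay compound 2 likewise gives > 50 ug/mL, again a limit rather than a measured number. So compound 2 stands at the top of what this test resolves, and no ordering between compound 1 and compound 2 can be read from these two values; both sit at the same limit (the limit of > 50 ug/mL in this assay, at which 2 of the 2 values shown sit).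

Compound 3 `Cc1cc(-c2cccc(O)c2)cn2c(CSCCc3ccccc3)cnc12` is not yet measured. It differs from compound 2 in one place: 3-hydroxyphenyl in place of iodo on an aromatic carbon. Going by the values given here, no measured pair in this set tracks a change of this kind, so there is nothing in the data to point toward a shift in either direction. The expectation for the step from compound 2 to compound 3 is therefore no step beyond the scatter a number no higher from compound 2 to compound 3 (the limit leaves the size open). Compound 3 is estimated at 50 ug/mL, with a range of 20 ug/mL to 100 ug/mL, and most likely the assay will again report only the limit for compound 3.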

Compound 3, half-maximal cytotoxic concentration: 50 ug/mL
Compound 3: middle estimate and measured number agree at the digits printed; the range from low to high includes it.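

In this assay, going by these compounds alone, compound 3 gives 50 ug/mL, the first value in this set that is a number and not a limit. The exchange of iodo for 3-hydroxyphenyl on this aromatic carbon, two atoms from the ring nitrogen, gives a number no higher from compound 2 to compound 3 (the limit leaves the size open), so this position carries a six-membered aromatic ring of carbon only, with a hydrogen-bond donor, and the read-out still stands at the level where the test stops resolving. What can be drawn from this is narrow, as the values crowd at one point: the limit of > 50 ug/mL in this assay, at which 2 of the 3 values shown sit.

The size of the step cannot be read, and the data do not separate the part played by the added ring from that of its hydroxy group. Also open, as far as these compounds go, is how an unsubstituted phenyl, an amine or a carboxylic acid on the same aromatic carbon would read in this assay, and whether the same exchange on the core of compound 1 would follow the same course.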